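Nitrile to Methyl: Expected Shift in Lipophilicity

The source may hold more compounds than are shown below. What is called first, only, known or untested is meant among the compounds shown, and "the series" means these compounds.

Of the compounds shown here, three have been measured in a physicochemical assay for lipophilicity; a higher number here means a more lipophilic compound, a lower number a more polar compound. Compound 1, `Cc1cc(C#N)cc(C)c1Oc1ccnc(Nc2ccc(C#N)cc2)n1`, gives 1.39. Compound 2, `Cc1cc(C)c(Oc2ccnc(Nc3ccc(C#N)cc3)n2)c(C)c1`, differs from compound 1 by methyl in place of cyano on an aromatic carbon. In this assay compound 2 gives 1.82, so that a number 0.43 log units higher from compound 1 to compound 2 (beyond the scatter). Compound 3, `Cc1cnc(Nc2ccc(C#N)cc2)nc1Nc1c(C)cc(C#N)cc1C`, gives 1.49 in this assay. The value of compound 3 and that of compound 1 lie within the scatter of each other, while compound 2 sits higher than compound 3 by a margin beyond the scatter. How the core of compound 3 differs from the core of compound 1 is not broken down here.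

Compound 4, `Cc1cc(C)c(Nc2nc(Nc3ccc(C#N)cc3)ncc2C)c(C)c1`, has not yet been measured in this assay. It differs from compound 3 by methyl in place of cyano on an aromatic carbon. This is the same change as the one from compound 1 to compound 2, and the surroundings of the place are described in the same words in both cases; among the compounds shown, the change occurs two times in all. Among the compounds with values here, only one measured example of the change exists, so the expectation rests on it alone. Because that single example gave a number 0.43 log units higher from compound 1 to compound 2 (beyond the scatter), a step of similar size is expected on the core of compound 3. For compound 4 the expected step is a number 0.43 log units higher from compound 3 to compound 4 (beyond the scatter). In this assay compound 4 is therefore estimated to give 1.92, with a likely range from 1.6 to 2.25.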

Compound 4, partition coefficient: 1.92
Compound 4: the middle estimate sits on the measured number at the digits printed; the range from low to high includes it.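

The new step is a number 0.43 log units higher from compound 3 to compound 4 (beyond the scatter) and the earlier one is a number 0.43 log units higher from compound 1 to compound 2 (beyond the scatter) in this assay, so methyl in place of cyano on an aromatic carbon gave steps of the same size at the digits printed on the two cores. Within this series, then, the step seen on the core of compound 1 carried over to the core of compound 3, and neither pair goes against that, but two pairs are a very small sample and set no rule for any core beyond these. Nothing measured here explains why the step came out as it did, so the result describes what happened and gives no mechanism for it.

The compounds shown leave open whether a step of this size would also appear on a core other than these two, and whether the nitrile that all four compounds share would respond in the same way if it were changed. They also leave open where compounds would fall with an amine, a carboxylic acid or a longer chain such as propyl in the place of the methyl, since these two pairs speak only for the swap from cyano to methyl.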